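The compounds below may be only part of what the source reports. "The series", "measured", "known", "first", "only" and "open" are said of these compounds alone.

In an ADME assay on the whole organism (plasma, strain BALB/c) for pharmacokinetics, with Mus musculus as the target, at a dose of 5 mg/kg by the oral route (on this read-out lower numbers stand for lower exposure and higher numbers for higher exposure at the dose given), compound 1 (`Cc1ccc(S(=O)(=O)N2CCOCC2)cc1C#Cc1cc(Cl)ccc1OCC(=O)O`) gives 1230 ng.h/mL and compound 2 (`CS(=O)(=O)c1ccc(F)c(C#Cc2cc(Cl)ccc2OCC(=O)O)c1`) gives 3240 ng.h/mL on the same scale. Compound 2 therefore holds the higher of the two numbers, and the gap between them lies beyond the usual scatter of repeated measurements. Compound 3 (`Cc1ccc(S(C)(=O)=O)cc1C#Cc1cc(Cl)ccc1OCC(=O)O`) differs from compound 2 at a single place, with methyl in place of fluoro on an aromatic carbon. Among the compounds with values here, no two measured compounds differ in one place only, so the data offer no direct guide to this change. The expectation is therefore a modest one: a slight fall in this assay at most, with no shift beyond the scatter. The estimated move (a 1.3-fold lower number from compound 2 to compound 3 (0.11 log units; within the scatter)) is small for that reason. The estimate for compound 3 is 2500 ng.h/mL (range 1000 ng.h/mL to 6000 ng.h/mL).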

Compound 3, area under the concentration-time curve: 1800 ng.h/mL
The estimate for compound 3 lay 1.4-fold (0.14 log units) above the measured number; low and high end bracket the measured number.
By their numbers in this assay, from the lowest: compounds 1, 3 and 2 (each within the scatter of the next, the first and the last beyond it).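

Within the data shown here, compound 3 gives the first single-change reading at this aromatic carbon, ortho to a large group and para to a methylsulfonyl group: in this assay, methyl in place of fluoro gives a 1.8-fold lower number from compound 2 to compound 3 (0.26 log units; within the scatter), so this swap cannot be told apart from the noise of repeat measurements. Among these compounds, it also gives the first single-change reading on the sulfonyl sulfur, where methyl in place of morpholin-4-yl gives a 1.5-fold higher number from compound 1 to compound 3 (0.17 log units; within the scatter), again with no clear difference. Nothing available here explains either step. From the compounds shown here alone, what chloro, methoxy or a nitrile would do on that aromatic carbon remains open. So does the effect of a small amine such as dimethylamino, or of a piperidine ring, on the sulfonyl sulfur.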